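Exchanging the Aryl Group on the Amine of Compound 2

The compounds below may be only part of what the source reports. "The series", "measured", "known", "first", "only" and "open" are said of these compounds alone.

In a functional assay on MGC-803 cells (Homo sapiens) for inhibition, read by sulforhodamine B assay (on this read-out higher numbers stand for weaker inhibition and lower numbers for stronger inhibition), compound 2 `COc1cccc(NC2=CC(=O)c3nc4n(c3C2=O)[C@H]2OC[C@@H](O)[C@H]2OC4)c1` gives 1780 nM, while compound 1 `COc1cccc(NC2=CC(=O)c3c(nc4n3[C@H]3OC[C@@H](O)[C@H]3OC4)C2=O)c1` gives 1790 nM; the two numbers lie within the scatter of each other. Compound 3 `O=C1C(N2CCCC2)=CC(=O)c2c1nc1n2[C@H]2OC[C@@H](O)[C@H]2OC1` reaches only the limit of > 16000 nM. Going by the values given here, the one measured step, an at least 8.9-fold higher number from compound 1 to compound 3 (0.95 log units; beyond the scatter), removes the aryl amine altogether, and bears only loosely on the present change. Compound 4 `CCCc1ccc(NC2=CC(=O)c3nc4n(c3C2=O)[C@H]2OC[C@@H](O)[C@H]2OC4)cc1` differs from compound 2 by 4-propylphenyl in place of 3-methoxyphenyl on an amine nitrogen. Both groups are one six-membered aromatic ring of carbon only, held on the same amine nitrogen. The step of a 1.1-fold higher number from compound 2 to compound 4 (0.05 log units; within the scatter) is therefore expected to stay within the scatter. Compound 4 is estimated at 2000 nM, between 700 nM and 6000 nM.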

Compound 4, half-maximal inhibitory concentration: 1560 nM
Compound 4: the middle estimate sits 1.3-fold (0.11 log units) above what was measured; the measured number falls inside the stated range.
By their numbers in this assay, from the lowest: compounds 4, 2 and 1 (each within the scatter of the next). At a limit, above all of these: compound 3.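

In this assay, the step of a 1.1-fold lower number from compound 2 to compound 4 (0.06 log units; within the scatter) shows that the aryl group on this amine nitrogen can change from 3-methoxyphenyl to 4-propylphenyl with no shift beyond the scatter. The oxygen of the methoxy group is therefore not required for this level of inhibition, at least in this pair. Nothing measured here explains why the two aryl groups give such similar numbers. Still open, on these data alone, is whether a phenyl ring carrying a carboxylic acid, an amine or a longer chain such as octyl would keep this level.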